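Chlorobenzyl position and arterial inhibition in three analogues

The compounds below may be only part of what the source reports. "The series", "measured", "known", "first", "only" and "open" are said of these compounds alone.

Measured in a functional assay on the whole organism (artery, strain albino) with Rattus norvegicus as the target, with a stated time of 15 min, at a dose of 10 mg/kg by the oral route; a lower number here means less inhibition, a higher number more inhibition at the dose given (going by the name of the read-out):
compound 1, `COc1ccc(C2N=C(SCc3ccccc3Cl)NC(C)=C2C(=O)Nc2ccc(F)cc2)cc1OC`: 2.6%
compound 2, `COc1ccc(C2N=C(SCc3cccc(Cl)c3)NC(C)=C2C(=O)Nc2ccc(F)cc2)cc1OC`: 2.1%
compound 3, `COc1ccc(C2N=C(SCc3ccccc3Cl)NC(C)=C2C(=O)Nc2ccc(Br)cc2)cc1`: 3.1%

Among the compounds with values here, all three numbers lie within the usual scatter of one another, so no compound can be set above or below the others. The change 3-chlorophenyl in place of 2-chlorophenyl on a saturated chain carbon bound to a sulfur occurs once between measured compounds, where it gave a number 0.5 percentage points lower from compound 1 to compound 2 (within the scatter). The cores of compound 1 and compound 3 differ in more than one place, and that difference is not broken down here. Compound 4, `COc1ccc(C2N=C(SCc3cccc(Cl)c3)NC(C)=C2C(=O)Nc2ccc(Br)cc2)cc1`, is the unmeasured partner of compound 3 and carries the same change, (3-chlorophenyl in place of 2-chlorophenyl on a saturated chain carbon bound to a sulfur). Because a number 0.5 percentage points lower from compound 1 to compound 2 (within the scatter) stayed within the scatter, the step of a number 0.5 percentage points lower from compound 3 to compound 4 (within the scatter) is expected to be small as well. Compound 4 is therefore estimated at 2.6% in this assay, with a range from -5% to 10%.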

Compound 4, a percentage reported as inhibition, in the whole organism at one dose (the size of the read-out at that dose, not a potency): 3.1%
Compound 4: middle estimate off by 0.5 percentage points, on the low side; measured number inside the range.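

In this assay, 3-chlorophenyl in place of 2-chlorophenyl on a saturated chain carbon bound to a sulfur gave no change at the digits printed from compound 3 to compound 4 (within the scatter). Set beside the earlier step, the change carried from one core to the other without a difference that can be told apart: the same change on two cores in this assay, a number 0.5 percentage points lower (within the scatter) from compound 1 to compound 2 and no change at the digits printed (within the scatter) from compound 3 to compound 4, 0.5 percentage points apart, within the scatter of two such steps This holds only for these two cores at this one oral dose, and it does not show that the change would behave the same way on any other core or at another dose.

Only chlorobenzyl groups stand on the sulfur in the compounds shown. From the compounds shown here alone, what a longer alkyl chain, an amine or a carboxylic acid in that place would give in this assay remains open.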